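Fluorine position on the pendant aryl ring in the shared core

The source may report more compounds than this note shows. Statements on the series, on what has been measured and on what is new or still open speak of the compounds shown alone.

Measured compounds in an assay on CHO cells for displacement of a labelled ligand from 5-hydroxytryptamine receptor 1D (Homo sapiens); a higher number here means a weaker inhibitor, a lower number a stronger inhibitor:
compound 1 `FC1(Cc2ccccc2)CCN(CCCc2c[nH]c3ccc(-n4cnnc4)cc23)CC1`: 0.9 nM
compound 2 `FC1(Cc2ccccc2C(F)(F)F)CCN(CCCc2c[nH]c3ccc(-n4cnnc4)cc23)CC1`: 0.3 nM
compound 3 `Fc1ccccc1CCC1(F)CCN(CCCc2c[nH]c3ccc(-n4cnnc4)cc23)CC1`: 0.8 nM

Compound 3 sits second of the three numbers. Its gap to compound 1 is within the scatter, as a 1.1-fold lower number from compound 1 to compound 3 (0.05 log units; within the scatter) shows, so the two cannot be ordered. Compound 2 gives the lowest number, and the gap a 2.7-fold higher number from compound 2 to compound 3 (0.43 log units; beyond the scatter) lies beyond the scatter.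

Compound 4 is `Fc1ccc(CCC2(F)CCN(CCCc3c[nH]c4ccc(-n5cnnc5)cc34)CC2)cc1`. It differs from compound 3 only in 4-fluorophenyl in place of 2-fluorophenyl on a saturated chain carbon, two bonds along the chain from a saturated ring carbon; the two share every atom and differ only in where the fluorine sits on that ring.

Among the compounds with values here, none of the measured steps moves a substituent around the aryl ring. The steps of a 3.0-fold lower number from compound 1 to compound 2 (0.48 log units; beyond the scatter) and a 2.7-fold higher number from compound 2 to compound 3 (0.43 log units; beyond the scatter) concern the introduction or removal of a trifluoromethyl group, not the placement of fluorine, so they give no direct guide. The series offers nothing that says this relocation should matter. Compound 4 is therefore expected to sit close to compound 3, with the step of a 1.3-fold higher number from compound 3 to compound 4 (0.10 log units; within the scatter) expected to stay within the scatter. The estimate for compound 4 in this assay is 1 nM, with a range from 0.4 nM to 2.5 nM.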

Compound 4, half-maximal inhibitory concentration: 1 nM
Compound 4: the middle estimate sits on the measured number at the digits printed; the range from low to high includes it.
By their numbers in this assay, from the lowest: compound 2; then compounds 3, 1 and 4 (each within the scatter of the next).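

In this assay, moving the fluorine from 2-fluorophenyl to 4-fluorophenyl on a saturated chain carbon, two bonds along the chain from a saturated ring carbon, gives a 1.3-fold higher number from compound 3 to compound 4 (0.10 log units; within the scatter). Within the data shown here, this is the first direct read of fluorine placement on the pendant ring, and these two placements cannot be told apart. The second comparison, 4-fluorobenzyl in place of phenyl, gives a 1.1-fold higher number from compound 1 to compound 4 (0.05 log units; within the scatter), so it does not separate the pair either, whereas 4-fluorobenzyl in place of 2-(trifluoromethyl)phenyl gives a 3.3-fold higher number from compound 2 to compound 4 (0.52 log units; beyond the scatter), leaving compound 2 as the only one of the four whose steps to all the others lie beyond the scatter; no accompanying data bear on this result.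

The compounds shown leave open whether the trifluoromethyl group would keep compound 2's advantage if it were carried on the pendant ring of compound 4 in place of the fluorine. They also leave open whether a group other than fluorine or trifluoromethyl on that ring, such as a nitrile, a methoxy or an amine, would respond to placement any differently from fluorine.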